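The source may hold more compounds than are shown below. What is called first, only, known or untested is meant among the compounds shown, and "the series" means these compounds.

Measured compounds:
Compound 1, `COc1ccc(CN(C(=O)CCl)c2cc(OC)c(OC)c(OC)c2)cc1O`: 84 nM
Compound 2, `C#CC(=O)N(Cc1ccc(OC)c(O)c1)c1cc(OC)c(OC)c(OC)c1`: 170 nM
Compound 3, `C=C(C)C(=O)N(Cc1ccc(OC)c(O)c1)c1cc(OC)c(OC)c(OC)c1`: 390 nM

The three compounds share one core and differ only in the group carried on the carbonyl carbon. In a functional assay on MGC-803 cells (Homo sapiens) for inhibition, read by MTT assay, with a stated time of 48 h (a lower number here means a stronger inhibitor, a higher number a weaker inhibitor), compound 1, with chloromethyl there, gives the lowest of the three numbers. Compound 2, with ethynyl, comes next: a 2.0-fold higher number from compound 1 to compound 2 (0.31 log units; beyond the scatter). Compound 3, with 1-methylethenyl, stands highest of the three; its nearest neighbour is compound 2 (a 2.3-fold higher number from compound 2 to compound 3 (0.36 log units; beyond the scatter)) and its furthest is compound 1 (a 4.6-fold higher number from compound 1 to compound 3 (0.67 log units; beyond the scatter)).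

Compound 4, `COc1ccc(CN(C(=O)C[Se]C#N)c2cc(OC)c(OC)c(OC)c2)cc1O`, has not yet been measured. It differs from compound 3 in one place: a group of 4 heavy atoms (2 carbon, 1 nitrogen, 1 selenium; no ring) in place of a group of 3 heavy atoms (3 carbon; no ring), on a carbonyl carbon. The entering group is, like the chloromethyl of compound 1, a saturated carbon bearing a single further substituent attached to the carbonyl carbon, whereas the 1-methylethenyl of compound 3 and the ethynyl of compound 2 are unsaturated. Among the measured steps, the one most relevant is therefore a 4.6-fold higher number from compound 1 to compound 3 (0.67 log units; beyond the scatter) read in reverse: replacing 1-methylethenyl by a saturated substituted methyl recovered potency. Going by the values given here, a step of similar size, toward a lower number, is expected here, though no measured pair shows this exact group, so the range is kept wide. The expected step is a 3.3-fold lower number from compound 3 to compound 4 (0.51 log units; beyond the scatter). Compound 4 is thus estimated at 120 nM, between 45 nM and 320 nM.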

Compound 4, half-maximal inhibitory concentration: 270 nM
For compound 4 the middle estimate is 2.3-fold (0.35 log units) below the measured one; the measured number falls inside the stated range.
By their numbers in this assay, from the lowest: compound 1; then compounds 2, 4 and 3 (each within the scatter of the next, the first and the last beyond it).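

In this assay, a saturated carbon bearing a single further substituent on the carbonyl carbon did not by itself give a number like that of compound 1. The selenium-bearing group of compound 4 cannot be told apart from 1-methylethenyl (a 1.4-fold lower number from compound 3 to compound 4 (0.16 log units; within the scatter)) or from ethynyl (a 1.6-fold higher number from compound 2 to compound 4 (0.20 log units; within the scatter)), while exchanging the chlorine of compound 1 for the rest of that group on the same saturated carbon leaves a gap beyond the scatter (a 3.2-fold higher number from compound 1 to compound 4 (0.51 log units; beyond the scatter)), so at this position what hangs on that carbon counts, not only whether the carbon is saturated. Nothing available bears on why this exchange separates the two compounds.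

The compounds shown leave open whether the low number of compound 1 is particular to chlorine or would also appear with a bromine atom, a thiocyanate or a plain methyl on that saturated carbon. They also leave open how a longer chain between the carbonyl carbon and the chlorine would read, and whether any of these differences persists when the hydroxyl or methoxy groups of the shared core are replaced.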